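Swapping the amide tail: methoxy out, chloromethyl in

The compounds below may be only part of what the source reports. "The series", "measured", "known", "first", "only" and "open" are said of these compounds alone.

Measured so far:
compound 1, `COCC(=O)N(Cc1ccc(OC)c(O)c1)c1cc(OC)c(OC)c(OC)c1`, 230 nM
compound 2, `COC(=O)c1cc(CNc2cc(OC)c(OC)c(OC)c2)ccc1OC`, 38100 nM
compound 3, `C/C=C/C(=O)N(Cc1ccc(OC)c(N)c1)c1cc(OC)c(OC)c(OC)c1`, 300 nM

All three compounds were tested in a functional assay on HCT-116 cells (Homo sapiens) for inhibition, read by MTT assay, with a stated time of 48 h; a lower number here means a stronger inhibitor, a higher number a weaker inhibitor. Compound 1 has the lowest number of the three. Its nearest neighbour is compound 3, whose value lies within the scatter of repeated measurements, so the two cannot be told apart. Compound 2, which carries no acyl group on its nitrogen and an ester on its outer ring, stands far beyond the scatter from both, giving 38100 nM.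

The unmeasured compound 4, `COc1ccc(CN(C(=O)CCCl)c2cc(OC)c(OC)c(OC)c2)cc1O`, keeps the core of compound 1 and differs from it in one place: chloromethyl in place of methoxy on a saturated chain carbon bound to a carbonyl carbon. The amide on the nitrogen is retained, only its tail changes.

Because compound 1 at 230 nM and compound 3 at 300 nM lie within the scatter of each other despite carrying different acyl tails, a change confined to that tail is expected to give, in this assay, no step beyond the scatter, or at most a small one in either direction. Compound 4 is therefore estimated to give 300 nM, with a range from 100 nM to 900 nM, which would mean a step of a 1.3-fold higher number from compound 1 to compound 4 (0.12 log units; within the scatter).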

Compound 4, half-maximal inhibitory concentration: 150 nM
Beside the measured number, compound 4's estimate is 2.0-fold (0.30 log units) above it; the range from low to high includes it.
By their numbers in this assay, from the lowest: compounds 4, 1 and 3 (each within the scatter of the next); then compound 2.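

In this assay, among the compounds shown here, the first pair that differs in one place shows that chloromethyl in place of methoxy on a saturated chain carbon bound to a carbonyl carbon gives a 1.5-fold lower number from compound 1 to compound 4 (0.19 log units; within the scatter) and so no change that can be told apart from the spread of repeated measurements. Compound 1 and compound 3 differ in more than one place, so their closeness could not speak for the amide tail alone, whereas this pair shows that the tail can exchange its oxygen for a chlorine, and lose the hydrogen-bond acceptor counted on methoxy, without a step beyond the scatter. Nothing available here explains why the two tails read alike.

The compounds shown leave open whether this place would also stay within the scatter with a different kind of group, such as an amine or a carboxylic acid, or with a longer chain ending in chlorine. They also leave open whether the same exchange of methoxy for chloromethyl would read alike on a shared core carrying an amine in place of the hydroxyl on the outer ring.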